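Swapping the side ring on a weak dopamine transporter inhibitor

The source may hold more compounds than are shown below. What is called first, only, known or untested is meant among the compounds shown, and "the series" means these compounds.

Of the compounds shown here, three have been measured in an assay on HEK293 cells for inhibition of sodium-dependent dopamine transporter (Homo sapiens), read by scintillation counting, with stated times of 5 min and 1 min; on this read-out higher numbers stand for weaker inhibition and lower numbers for stronger inhibition. Compound 1 `[O-][S+](Cc1cccs1)C(c1ccc(Cl)cc1)c1ccc(Cl)cc1` gives 7200 nM, and compound 3 `[O-][S+](Cc1cccs1)C(c1ccc(F)cc1)c1ccc(F)cc1` gives 4000 nM. Compound 2 `Cc1scc(C[S+]([O-])C(c2ccccc2)c2ccccc2)c1C` gives 284000 nM, the highest of the three numbers and therefore the weakest inhibition recorded here; its gap to compound 1 and its larger gap to compound 3 both lie well beyond the usual scatter. Within the data shown here, compound 1 and compound 3 differ from compound 2 in more than one place, so no single-change step can be drawn between them.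

Compound 4 `[O-][S+](Cc1csc(Br)c1)C(c1ccccc1)c1ccccc1` has not yet been measured. It differs from compound 2 in one place: 5-bromothiophen-3-yl in place of 4,5-dimethylthiophen-3-yl on a saturated chain carbon bound to a sulfur. Among the measured compounds shown here, both carry the same two unsubstituted phenyl rings on the shared core, so the comparison with compound 2 is the only direct guide, and the two stronger compounds, 1 and 3, cannot tell how much of their advantage comes from their side ring alone.

Given that compound 2 sits at 284000 nM, the expectation for compound 4 is a moderate step toward stronger inhibition, a 5.7-fold lower number from compound 2 to compound 4 (0.75 log units; beyond the scatter), though a result within the scatter would not be surprising. Compound 4 is estimated at 50000 nM, with a likely range from 12000 nM to 200000 nM.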

Compound 4, half-maximal inhibitory concentration: 16600 nM
Estimate against measurement, compound 4: 3.0-fold (0.48 log units) above; low and high end bracket the measured number.
By their numbers in this assay, from the lowest: compounds 3 and 1 (each within the scatter of the next); then compound 4; then compound 2.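

On this assay, exchanging the 4,5-dimethylthiophen-3-yl group for a 5-bromothiophen-3-yl group gives a 17-fold lower number from compound 2 to compound 4 (1.23 log units; beyond the scatter), so the side ring alone can shift the result by a large margin while the two unsubstituted phenyl rings stay the same. The step also keeps the ring type: both groups are five-membered aromatic rings with one hetero atom and have the same hydrogen-bond donor and acceptor counts and no net charge, so the visible difference lies in what the ring carries, two methyl groups in one case and a bromine in the other. Nothing available here explains why the number falls, and the size of the step remains an observation without a measured cause.

This single swap removes the methyl groups and adds the bromine together, so it cannot show how much each part contributes. A plain thiophen-3-yl ring would help separate the two, while a chlorine in place of the bromine, or an amine on the ring, would show how specific the requirement at this position is.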